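Exchanging the benzimidazole group of compound 3

The source may report more compounds than this note shows. Statements on the series, on what has been measured and on what is new or still open speak of the compounds shown alone.

Results in a functional assay on HL-60 cells (Homo sapiens) for antiproliferative activity, read by MTT assay, with a stated time of 48 h; on this read-out lower numbers stand for stronger inhibition and higher numbers for weaker inhibition:
compound 1 `CN(C)CCn1c(N)c(-c2nc3ccccc3n2C)c2nc(C#N)c(C#N)nc21`: > 50000 nM
compound 2 `CCN(CC)CCCn1c(N)c(-c2nc3ccccc3n2C)c2nc(C#N)c(C#N)nc21`: 2810 nM
compound 3 `CCN(CC)CCCCn1c(N)c(-c2nc3ccccc3n2C)c2nc(C#N)c(C#N)nc21`: 700 nM

Compound 1 sits at a limit of the assay, > 50000 nM. Compound 3 has the lowest number of the set at 700 nM, and the nearest number belongs to compound 2 at 2810 nM.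

Compound 4 `CCN(CC)CCCCn1c(N)c(-c2nc3cc(Cl)ccc3[nH]2)c2nc(C#N)c(C#N)nc21` keeps the 4-(diethylamino)butyl group of compound 3 but carries 5-chloro-1H-benzimidazol-2-yl in place of 1-methyl-1H-benzimidazol-2-yl on an aromatic carbon. Going by the values given here, all the measured steps lie in the saturated chain instead. Two are large, an at least 17-fold lower number from compound 1 to compound 2 (1.25 log units; beyond the scatter) and an at least 71-fold lower number from compound 1 to compound 3 (1.85 log units; beyond the scatter), and both start from a limit. The third is modest, a 4.0-fold lower number from compound 2 to compound 3 (0.60 log units; beyond the scatter). None of them touches the exchanged group, so they offer only a rough scale. A modest step towards a lower number in this assay is expected, with little certainty about its direction. The expected change is a 2.0-fold lower number from compound 3 to compound 4 (0.30 log units; within the scatter). For compound 4 the estimated value is 350 nM, with an expected range of 80 nM to 1800 nM.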

Compound 4, half-maximal inhibitory concentration: 820 nM
For compound 4 the middle estimate is 2.3-fold (0.37 log units) below the measured one, and the stated range covers the measured number.
By their numbers in this assay, from the lowest: compounds 3 and 4 (each within the scatter of the next); then compound 2. At a limit, above all of these: compound 1.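

In this assay the exchange at this aromatic carbon gives a 1.2-fold higher number from compound 3 to compound 4 (0.07 log units; within the scatter), so the two compounds cannot be told apart on this read-out. Going by these compounds alone, this is the first measured step at this position, and it shows that 1-methyl-1H-benzimidazol-2-yl can give way to 5-chloro-1H-benzimidazol-2-yl, which adds a chlorine and a hydrogen-bond donor, with the 4-(diethylamino)butyl group in place and no separation in the read-out. Nothing given here offers an explanation for this outcome.

The exchange alters two features at once, so the part played by the chlorine and the part played by the ring nitrogen methyl remain unseparated. From the compounds shown here alone, the parent 1H-benzimidazol-2-yl group and 5-chloro-1-methyl-1H-benzimidazol-2-yl would be needed to separate them, and the effect of the exchange on the shorter 3-(diethylamino)propyl chain also stays open.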